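Series notes: trifluoromethyl in place of bromo, compound 3

The compounds below may be only part of what the source reports. "The series", "measured", "known", "first", "only" and "open" are said of these compounds alone.

Measured so far:
compound 1, `COc1cc(/C=N/Nc2nc(-c3ccc(Br)cc3)cs2)cc(Br)c1OC`, gives 52300 nM in a functional assay on A549 cells (Homo sapiens) for inhibition, read by MTT assay, with a stated time of 48 h; on this read-out higher numbers stand for weaker inhibition and lower numbers for stronger inhibition.
compound 2, `COc1cc(/C=N/Nc2nc(-c3cccc(Br)c3)cs2)cc(Br)c1OC`, gives 56000 nM in this assay.

Among the measured compounds shown here, compound 1 and compound 2 cannot be told apart on these numbers; the single measured step, a 1.1-fold higher number from compound 1 to compound 2 (0.03 log units; within the scatter), moves the bromine within the ring and nothing more. Compound 1 therefore stands as one of two equivalent points, with no measured step beyond the scatter anywhere in the set.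

Compound 3, `COc1cc(/C=N/Nc2nc(-c3ccc(C(F)(F)F)cc3)cs2)cc(Br)c1OC`, differs from compound 1 by trifluoromethyl in place of bromo on an aromatic carbon. For the measured compounds named here, no measured step covers a swap of the bromo for another group; the one step known bears on position, not on identity, so it says nothing direct about this change. With nothing in the data pointing either way, the expected step in this assay is none beyond the scatter, and the range must stay wide.

Compound 3 is estimated at 55000 nM, between 25000 nM and 120000 nM, which means an expected step of a 1.1-fold higher number from compound 1 to compound 3 (0.02 log units; within the scatter) from compound 1.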

Compound 3, half-maximal inhibitory concentration: 18300 nM
Compound 3: the middle estimate sits 3.0-fold (0.48 log units) above what was measured; the measured number lies below the stated range.
By their numbers in this assay, from the lowest: compound 3; then compounds 1 and 2 (each within the scatter of the next).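

In this assay, among the compounds shown here, with trifluoromethyl in place of bromo, the series shows a 2.9-fold lower number from compound 1 to compound 3 (0.46 log units; beyond the scatter), the first step in the set beyond the scatter, though only a modest one. This shows that the identity of the group at this place can shift the read-out, which the earlier pair could not show: moving the bromine gave only a 1.1-fold higher number from compound 1 to compound 2 (0.03 log units; within the scatter), and the group itself stayed the same. No measurement at hand bears on what lies behind the step, so it stands as an observation on a single pair.

As far as these compounds go, it remains open whether this lower number is particular to trifluoromethyl or would also appear with another group at this place, such as a nitrile, an amine or a carboxylic acid. Also unresolved is whether trifluoromethyl would give a similar step at the place the bromine holds in compound 2, and what the second bromo of the shared core contributes, since it is unchanged across the three compounds.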